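This account rests on a few compounds, and the source may have more. Where it says the series, first, only, none or still open, it means among the compounds named here.

Measured compounds:
Compound 1 `CC(C(=O)N1CCCCCC1)N1CCN(S(=O)(=O)c2ccc(C(C)(C)C)cc2)CC1`: in an ADME assay on HepG2 cells (Homo sapiens) for inhibition, with a stated time of 48 h (on this read-out lower numbers stand for an effect already at smaller amounts and higher numbers for an effect only at larger amounts of compound), compound 1 gives > 40000 nM, which is a limit of the assay and not a number.
Compound 2 `CC(C(=O)N1CCC(C)(C)CC1)N1CCN(S(=O)(=O)c2ccc(C(C)(C)C)cc2)CC1`: in this assay compound 2 gives > 40000 nM, again a limit of the assay.
Compound 3 `CC(C(=O)N1CCOCC1)N1CCN(S(=O)(=O)c2ccc(C(C)(C)C)cc2)CC1`: in this assay compound 3 gives > 40000 nM, once more a limit of the assay.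

Compound 3 therefore stands at a limit rather than at a number, and the two further values shown are limits as well, so that the limit of > 40000 nM in this assay, at which 3 of the 3 values shown sit, describes all three. The steps that change the amide ring, a step that the two limits leave unreadable from compound 1 to compound 2, a step that the two limits leave unreadable from compound 1 to compound 3 and a step that the two limits leave unreadable from compound 2 to compound 3, are all left unreadable by the two limits, and none of them gives a size that could be carried forward.

Compound 4 `CC(C(=O)N1CCc2ccccc21)N1CCN(S(=O)(=O)c2ccc(C(C)(C)C)cc2)CC1` differs from compound 3 in one place: 2,3-dihydro-1H-indol-1-yl in place of morpholin-4-yl on a carbonyl carbon. The three unreadable steps bear on it only in that every change of the ring on the carbonyl carbon so far has stayed at the limit. The expectation for compound 4 is accordingly a step of a number no higher from compound 3 to compound 4 (the limit leaves the size open) in this assay, that is, none beyond the scatter. Compound 4 is estimated at 40000 nM, within a range from 15000 nM to 100000 nM, with the outcome most likely again reported as a limit.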

Compound 4, half-maximal effective concentration: > 40000 nM
Compound 4 ended at the assay's limit (the forecaster's own chance of this, stated with the estimate: 80%); the middle value lies on the limit itself.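

In this assay compound 4 gives > 40000 nM, which is a limit of the assay and not a number. Its steps to compound 1, compound 2 and compound 3 therefore cannot be read. The compounds shown leave open whether any change of the ring on the carbonyl carbon moves the read-out, as all share one value: the limit of > 40000 nM in this assay, at which 4 of the 4 values shown sit.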